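The source may hold more compounds than are shown below. What is called first, only, known or untested is meant among the compounds shown, and "the series" means these compounds.

Compound 1 `Cn1c(-c2ccc(NC(=O)CN3CCN(Cc4ccccc4)CC3)cc2)nc(-c2ccccc2)c1-c1ccccc1`: 13.3%
Compound 2 `Cc1ccc(CN2CCN(CC(=O)Nc3ccc(-c4nc(-c5ccccc5)c(-c5ccccc5)n4C)cc3)CC2)cc1`: 19.3%

Both were run in a functional assay on MCF7 cells (Homo sapiens) for cytotoxicity, read by MTT assay, with a stated time of 24 h, tested at 1.6 ug/mL; a higher number here means a stronger effect of the compound at the concentration tested, a lower number a weaker effect. Compound 2 holds the higher of the two numbers, but the step of a number 6 percentage points higher from compound 1 to compound 2 (within the scatter) stays inside the scatter, so compound 1 and compound 2 cannot be told apart on this read-out. Compound 3 `Cn1c(-c2ccc(NC(=O)CN3CCN(Cc4ccc(Cl)cc4)CC3)cc2)nc(-c2ccccc2)c1-c1ccccc1` is still to be measured. The change from compound 2: chloro in place of methyl on an aromatic carbon. Among the compounds with values here, no measured step carries this change; the only step known, a number 6 percentage points higher from compound 1 to compound 2 (within the scatter), touches a different group and was itself within the scatter. A shift not beyond the scatter is therefore expected. Compound 3 is estimated at 18% (range 7% to 32%). That estimate means an expected step of a number 1.3 percentage points lower from compound 2 to compound 3 (within the scatter).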

Compound 3, a percentage reported as activity, at one concentration (the size of the read-out at that concentration, not a potency): 11.8%
Compound 3: the middle estimate sits 6.2 percentage points above what was measured, and the stated range covers the measured number.
By their numbers in this assay, from the lowest: compounds 3, 1 and 2 (each within the scatter of the next).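

Chloro on the aromatic carbon para to a large group gives a number 7.5 percentage points lower from compound 2 to compound 3 (within the scatter) against methyl and a number 1.5 percentage points lower from compound 1 to compound 3 (within the scatter) against hydrogen in this assay at this position. Hydrogen, methyl and chloro at this carbon therefore cannot be told apart on this read-out, and the flat reading first seen with methyl now extends to a second substituent. Nothing available offers an explanation for this.

From the compounds shown here alone, whether a methoxy group, a trifluoromethyl group or an amine at this carbon would move the number beyond the scatter stays open. So does whether a change in the shared core would matter more.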